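Adding a second chloro to a urea-bearing aryl amide series

The source may hold more compounds than are shown below. What is called first, only, known or untested is meant among the compounds shown, and "the series" means these compounds.

Measured compounds:
- compound 1, `CN(C)CCCNc1nc(-c2ccc(NC(=O)Nc3ccccc3Cl)cc2)nc2ccsc12`: 390 nM
- compound 2, `CN(C)CCCNc1nc(-c2ccc(NC(=O)Nc3ccc(Cl)cc3Cl)cc2)nc2ccsc12`: 1860 nM
- compound 3, `CN(C)CCNc1nc(-c2ccc(NC(=O)Nc3ccccc3Cl)cc2)nc2ccsc12`: 310 nM

All three compounds were tested in a functional assay on HT-29 cells (Homo sapiens) for cytotoxicity, read by MTT assay, with a stated time of 72 h; on this read-out higher numbers stand for weaker inhibition and lower numbers for stronger inhibition. Compound 1 gives 390 nM, compound 2 gives 1860 nM, and compound 3 gives 310 nM. Compounds 1 and 2 differ in one place, (chloro in place of hydrogen on an aromatic carbon), and this gave a 4.8-fold higher number from compound 1 to compound 2 (0.68 log units; beyond the scatter). Compounds 1 and 3 differ in the chain that joins the shared core to the dimethylamino group, (dimethylamino in place of (dimethylamino)methyl on a saturated chain carbon, two bonds along the chain from a nitrogen on an aromatic ring), and this gave a 1.3-fold lower number from compound 1 to compound 3 (0.10 log units; within the scatter), so compounds 1 and 3 cannot be told apart on this read-out.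

Compound 4, `CN(C)CCNc1nc(-c2ccc(NC(=O)Nc3ccc(Cl)cc3Cl)cc2)nc2ccsc12`, has not yet been measured in this assay. It stands to compound 3 as compound 2 stands to compound 1: the change is chloro in place of hydrogen on an aromatic carbon, the same change as before, made on the shorter chain. Because the step of a 4.8-fold higher number from compound 1 to compound 2 (0.68 log units; beyond the scatter) was beyond the scatter, the expectation for compound 4 is a similar weakening, estimated as a 4.8-fold higher number from compound 3 to compound 4 (0.68 log units; beyond the scatter), which rests on one measured pair only. In this assay compound 4 is therefore expected to give about 1500 nM, most likely between 600 nM and 3800 nM.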

Compound 4, half-maximal inhibitory concentration: 1320 nM
The estimate for compound 4 lay 1.1-fold (0.06 log units) above the measured number; measured number inside the range.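

Moving from the 2-chlorophenyl to the 2,4-dichlorophenyl group on the shorter chain gave a 4.3-fold higher number from compound 3 to compound 4 (0.63 log units; beyond the scatter) and so repeated what the same change did on the longer chain: the same change on two cores in this assay, a 4.8-fold higher number (0.68 log units; beyond the scatter) from compound 1 to compound 2 and a 4.3-fold higher number (0.63 log units; beyond the scatter) from compound 3 to compound 4, 1.1-fold (0.05 log units) apart, within the scatter of two such steps. Shortening the chain with the 2,4-dichlorophenyl group in place gave a 1.4-fold lower number from compound 2 to compound 4 (0.15 log units; within the scatter) and so left compound 2 and compound 4 indistinguishable, just as the chain change did with the 2-chlorophenyl group: the same change on two cores in this assay, a 1.3-fold lower number (0.10 log units; within the scatter) from compound 1 to compound 3 and a 1.4-fold lower number (0.15 log units; within the scatter) from compound 2 to compound 4, 1.1-fold (0.05 log units) apart, within the scatter of two such steps. Together these pairs show that, across these two chains, the added chloro and the chain length can each be read on their own, but this rests on four compounds and does not show why the chloro raises the number or whether the same step would appear on a core changed elsewhere.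

The compounds shown leave open whether another group at the same place on the ring, such as fluoro, methyl or methoxy, would raise the number as chloro does. They also leave open whether the chloro step would hold with a longer chain or with a different amine, such as morpholine or piperidine, at the end of the chain.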